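The source may hold more compounds than are shown below. What is called first, only, known or untested is meant among the compounds shown, and "the series" means these compounds.

Working notes on the series. Compound 1 `Cc1c(C(=O)N/N=C/c2ccc(N(C)C)cc2)no[n+]1[O-]` carries dimethylamino on the aryl ring; in an ADME assay on J774.1 cells (Mus musculus) for cytotoxicity, read by MTT assay, with a stated time of 48 h (a higher number here means a weaker inhibitor, a lower number a stronger inhibitor), compound 1 gives 129000 nM. Compound 2 `Cc1c(C(=O)N/N=C/c2ccccc2)no[n+]1[O-]` is the unsubstituted phenyl analogue; in this assay compound 2 gives only the limit > 400000 nM. Compound 3 `Cc1c(C(=O)N/N=C/c2ccccn2)no[n+]1[O-]` carries pyridin-2-yl; in this assay compound 3 gives only the limit > 400000 nM. Compound 2 therefore sits at the limit of > 400000 nM in this assay, at which 2 of the 3 values shown sit, at the weak end of what is shown. The step of an at least 3.1-fold higher number from compound 1 to compound 2 (0.49 log units; beyond the scatter) shows that removing dimethylamino raises the number; the step that the two limits leave unreadable from compound 2 to compound 3 cannot be read. Compound 4 `CC(=O)Nc1ccc(/C=N/NC(=O)c2no[n+]([O-])c2C)cc1` differs from compound 2 by acetamido in place of hydrogen on an aromatic carbon. Because compound 1 with a substituent there gives 129000 nM, a readable number for compound 4 is plausible but uncertain. Compound 4 is expected at 250000 nM, within 100000 nM to 500000 nM. This estimate means an expected step of an at least 1.6-fold lower number from compound 2 to compound 4 (0.20 log units; that floor lies within the scatter).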

Compound 4, half-maximal inhibitory concentration: 235000 nM
The estimate for compound 4 lay 1.1-fold (0.03 log units) above the measured number; measured number inside the range.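

In this assay, a second group on the aromatic carbon para to a large group also gives a readable number: acetamido in place of hydrogen gives an at least 1.7-fold lower number from compound 2 to compound 4 (0.23 log units; that floor lies within the scatter). Acetamido and dimethylamino at this position cannot be told apart, with a 1.8-fold higher number from compound 1 to compound 4 (0.26 log units; within the scatter). Going by these compounds, the full size of the step from hydrogen stays unknown, since compound 2 gives only a limit: the limit of > 400000 nM in this assay, at which 2 of the 4 values shown sit. On these data alone, whether a carboxylic acid or a simple amine on this aromatic carbon would also give a readable number remains open.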